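From 4-methylphenyl to 2-nitrophenyl on a sulfonyl sulfur

This account rests on a few compounds, and the source may have more. Where it says the series, first, only, none or still open, it means among the compounds named here.

Compound 1 `N#C/C(=C\c1ccccc1OS(=O)(=O)c1ccccc1[N+](=O)[O-])C(=O)Nc1nnc(Cc2cccc3ccccc23)s1`: "not toxic" (no number reported)
Compound 2 `N#C/C(=C\c1ccccc1OS(=O)(=O)c1ccccc1[N+](=O)[O-])C(=O)Nc1nnc(Cc2ccc(F)cc2)s1`: 6%
Compound 3 `Cc1ccc(S(=O)(=O)Oc2ccccc2/C=C(\C#N)C(=O)Nc2nnc(Cc3ccc(Cl)cc3)s2)cc1`: 20%

In an ADME assay on HEK-293T cells (Homo sapiens) for inhibition, read by CCK-8 assay, with a stated time of 48 h, tested at 20 uM (on this read-out lower numbers stand for less inhibition of growth and higher numbers for more inhibition of growth at the one concentration tested), compound 3 gives 20%, the higher of the two numbers available and clear of compound 2 by more than the usual scatter. Compound 1 has no number. Compound 4 `N#C/C(=C\c1ccccc1OS(=O)(=O)c1ccccc1[N+](=O)[O-])C(=O)Nc1nnc(Cc2ccc(Cl)cc2)s1` differs from compound 3 by one change, 2-nitrophenyl in place of 4-methylphenyl on a sulfonyl sulfur. Compound 1 and compound 2 already carry 2-nitrophenyl, though each also differs from compound 4 elsewhere, so this evidence is indirect. Compound 2 gives 6%, and compound 1 is reported as "not toxic" (no number reported). A downward move is therefore expected, and the estimated step is a number 9 percentage points lower from compound 3 to compound 4 (within the scatter). The expected value for compound 4 is 11%, within an estimated range from 2% to 24%.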

Compound 4, percent growth inhibition at one concentration: 20%
Compound 4: middle estimate off by 9 percentage points, on the low side; measured number inside the range.
By their numbers in this assay, from the lowest: compound 2; then compounds 3 and 4 (each within the scatter of the next).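

In this assay the direct pair shows that 2-nitrophenyl in place of 4-methylphenyl on a sulfonyl sulfur gives no change at the digits printed from compound 3 to compound 4 (within the scatter) at this position. Chloro in place of fluoro on an aromatic carbon gives a number 14 percentage points higher from compound 2 to compound 4 (beyond the scatter) with the 2-nitrophenyl group held constant, so that group alone does not set the low number of compound 2. Nothing here gives a reason for either step.

Still open, going by these compounds, is how a 4-aminophenyl or a plain methyl on the sulfonyl sulfur would read. Bromo on that aromatic carbon also remains open.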